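The source may report more compounds than this note shows. Statements on the series, on what has been measured and on what is new or still open speak of the compounds shown alone.

Measured compounds:
- compound 1, `N#Cc1ccc(N2CCc3cc(-c4cncnc4)ccc32)cc1C(F)(F)F`: "not determined" (no result reported)
- compound 2, `CCN(c1ccc(C#N)c(Cl)c1)c1cc(-c2cccs2)ccc1C`: "not determined" (no result reported)
- compound 3, `CCN(c1ccc(C#N)c(C(F)(F)F)c1)c1cc(-n2ccnc2)ccc1C`: >= 3920 nM

The three compounds were tested in a functional assay on VCaP cells (Homo sapiens) for antiproliferative activity, read by CCK-8 assay, with a stated time of 6 days; on this read-out lower numbers stand for stronger inhibition and higher numbers for weaker inhibition. For compound 1 this assay reports "not determined" (no result reported), and compound 2 likewise has "not determined" (no result reported), so compound 2 stands without any number of its own. Compound 3 gives >= 3920 nM in this assay, and that entry is a limit of the assay rather than a number; (the limit of >= 3920 nM in this assay, at which 1 of the 3 values shown sits).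

The unmeasured compound 4, `CCN(c1ccc(C#N)c(Cl)c1)c1cc(-n2cccn2)ccc1C`, is built from compound 2 by one change: 1H-pyrazol-1-yl in place of thiophen-2-yl on an aromatic carbon. Going by the values given here, no measured step links compound 2 and compound 4, so the size of the step in this assay cannot be taken from measured pairs. Among the compounds with values here, with the only number-bearing entry being the limit of compound 3, any step is expected to sit in the weak region of the assay, with no clear direction beyond the scatter. Compound 4 is therefore estimated at 4000 nM, with a range from 1000 nM to 20000 nM.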

Compound 4, half-maximal inhibitory concentration: 2340 nM
Compound 4: middle estimate off by 1.7-fold (0.23 log units), on the high side; measured number inside the range.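

Going by these compounds alone, no step from compound 2 to compound 4 can be read: compound 2 carries no single number in this assay, while compound 4 gives 2340 nM. The compounds shown leave open whether 1H-pyrazol-1-yl in place of thiophen-2-yl changes the inhibition at all, and in which direction.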